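Amide aryl variation on a shared core: compounds 1 to 4

A few compounds are considered here, and "the series" means these few. Any claim that something is new, unique, unknown or untested is made for them only; others in the source may bear on it.

Measured in a functional assay on HepG2 cells (Homo sapiens) for antiproliferative activity, read by CCK-8 assay, with a stated time of 72 h; a higher number here means a weaker inhibitor, a lower number a stronger inhibitor:
- compound 1, `COc1ccc(C(=O)Nc2cccc(-c3oc4cc(-c5ccc(F)cc5)ccc4c(=O)c3O)c2)cc1`, gives 8420 nM
- compound 2, `COc1ccccc1C(=O)Nc1cccc(-c2oc3cc(-c4ccc(F)cc4)ccc3c(=O)c2O)c1`, gives 14500 nM
- compound 3, `Cc1cc(C)cc(C(=O)Nc2cccc(-c3oc4cc(-c5ccc(F)cc5)ccc4c(=O)c3O)c2)c1`, gives 13400 nM

Compound 3 sits second highest of the three numbers. Its nearest neighbour is compound 2, with a 1.1-fold lower number from compound 2 to compound 3 (0.03 log units; within the scatter); its furthest is compound 1, with a 1.6-fold higher number from compound 1 to compound 3 (0.20 log units; within the scatter). Neither gap separates compound 3 from the others.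

Compound 4, `CCCc1ccc(C(=O)Nc2cccc(-c3oc4cc(-c5ccc(F)cc5)ccc4c(=O)c3O)c2)cc1`, carries the change (4-propylphenyl in place of 3,5-dimethylphenyl on a carbonyl carbon). All three measured steps bear on this, since each swaps the aryl group on the same carbonyl carbon while the rest of the molecule is held: a 1.7-fold higher number from compound 1 to compound 2 (0.24 log units; within the scatter), a 1.6-fold higher number from compound 1 to compound 3 (0.20 log units; within the scatter) and a 1.1-fold lower number from compound 2 to compound 3 (0.03 log units; within the scatter). Every one of them stays inside the scatter, so across a methoxy shift, a change to two methyls and a change between those, this assay has not moved beyond noise. A further aryl swap to 4-propylphenyl is therefore expected to give no step beyond the scatter in this assay in either direction.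

The number for compound 4 is estimated at 12000 nM, with a range of 5500 nM to 26000 nM, which corresponds to an expected step of a 1.1-fold lower number from compound 3 to compound 4 (0.05 log units; within the scatter).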

Compound 4, half-maximal inhibitory concentration: 51500 nM
For compound 4 the middle estimate is 4.3-fold (0.63 log units) below the measured one; measured number outside the range, above it.
By their numbers in this assay, from the lowest: compounds 1, 3 and 2 (each within the scatter of the next); then compound 4.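

In this assay, the aryl group on the carbonyl carbon is no longer a silent variable: a 3.8-fold higher number from compound 3 to compound 4 (0.58 log units; beyond the scatter) and a 3.6-fold higher number from compound 2 to compound 4 (0.55 log units; beyond the scatter) lie beyond the scatter, unlike every step among compounds 1, 2 and 3. The sharpest comparison is a 6.1-fold higher number from compound 1 to compound 4 (0.79 log units; beyond the scatter) with propyl in place of methoxy on an aromatic carbon and the rest of the molecule held, so this single substituent change is enough to separate two compounds in this series, although all three new steps remain modest. Within the data shown here, compound 4 is thus the weakest of the four compounds, and 4-propylphenyl is the only aryl group here that stands apart from the others, while nothing available explains that separation.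

A single propyl example leaves open whether the loss follows chain length, and a methyl, ethyl or butyl group on the same aromatic carbon would be needed to trace that trend. How an amine or a carboxylic acid on that carbon would read in this assay also remains open, as does whether any such group could improve on the compounds shown.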